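A few compounds are considered here, and "the series" means these few. Any claim that something is new, unique, unknown or untested is made for them only; others in the source may bear on it.

Measured compounds: compound 1 `O=C(Nc1ccccc1C(F)(F)F)C1CCc2ccccc2N1C(=O)c1cccc(Cl)c1` with 292 nM; compound 2 `O=C(Nc1ccccc1O)C1CCc2ccccc2N1C(=O)c1cccc(Cl)c1` with 11600 nM; compound 3 `O=C(Nc1cc(C(F)(F)F)cc(C(F)(F)F)c1)C1CCc2ccccc2N1` with 8410 nM.

Read-out in all cases is a functional assay on NCI-H23 cells (Homo sapiens) for cytotoxicity, read by sulforhodamine B assay, with a stated time of 72 h; on this read-out lower numbers stand for stronger inhibition of growth and higher numbers for weaker inhibition of growth. Compound 1 gives the lowest number of the three; its nearest neighbour on the numbers is compound 3, and compound 2 lies furthest. Going by the values given here, the only single-point step among the measured compounds is a 40-fold higher number from compound 1 to compound 2 (1.60 log units; beyond the scatter), and it sits on the anilide aryl, not on the acyl attached to the ring nitrogen. Compound 3 carries no acyl on the ring nitrogen at all, but it also differs from compound 1 in its anilide aryl, so its value shows only that the combination it carries gives a much weaker number than compound 1.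

Compound 4 `CCC(=O)N1c2ccccc2CCC1C(=O)Nc1ccccc1C(F)(F)F` is the next compound: ethyl in place of 3-chlorophenyl on a carbonyl carbon. Among the compounds with values here, no measured step bears directly on this change. The change removes the only aromatic ring on that carbonyl; compound 3, lacking the acyl entirely, is weak, which gives a loose hint of direction. A rise is expected, a 5.1-fold higher number from compound 1 to compound 4 (0.71 log units; beyond the scatter), with wide uncertainty. Compound 4 is estimated at 1500 nM, within 400 nM to 6000 nM.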

Compound 4, concentration for 50% growth inhibition: > 80000 nM
Compound 4 was reported as a limit; the forecaster's own chance of this, stated with the estimate: 5%; at least 53-fold (1.72 log units) between middle value and limit.
By their numbers in this assay, from the lowest: compound 1; then compounds 3 and 2 (each within the scatter of the next). At a limit, above all of these: compound 4.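

In this assay, compound 4 stands only at a limit of the assay, not at a number: the limit of > 80000 nM in this assay, at which 1 of the 4 values shown sits. Going by these compounds alone, this is the first measured step at the carbonyl carbon on the amide-type nitrogen in a ring, and ethyl in place of 3-chlorophenyl gives an at least 270-fold higher number from compound 1 to compound 4 (2.43 log units; beyond the scatter). Growth inhibition in this series therefore depends on the acyl group as well as on the anilide aryl, where the only earlier step lay.

This single exchange removes the chlorine and the aromatic ring together, so the compounds shown do not separate their contributions. An unsubstituted benzoyl group, a longer chain such as butanoyl, or a cyclohexylcarbonyl group would show whether the ring, its aromatic character or the chlorine carries the difference.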